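A few compounds are considered here, and "the series" means these few. Any claim that something is new, unique, unknown or untested is made for them only; others in the source may bear on it.

Measured so far:
- compound 1, `COc1cc(NCc2ccccc2)cc(OC)c1OC`, gives > 80000 nM
- compound 2, `COCC(=O)N(Cc1ccc(OC)c(O)c1)c1cc(OC)c(OC)c(OC)c1`, gives 79 nM
- compound 3, `C/C=C/C(=O)N(Cc1ccc(OC)c(Br)c1)c1cc(OC)c(OC)c(OC)c1`, gives 6430 nM

All three carry the same trimethoxyphenyl-bearing core. In a functional assay on MGC-803 cells (Homo sapiens) for inhibition, read by MTT assay, with a stated time of 48 h (on this read-out lower numbers stand for stronger inhibition and higher numbers for weaker inhibition), compound 2 stands lowest of the two numbers recorded. Its nearest neighbour is compound 3, whose value sits far higher, well beyond the usual scatter. Compound 1 gives no number at all but only a limit, (the limit of > 80000 nM in this assay, at which 1 of the 3 values shown sits), so it cannot be placed in order against the others.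

The next compound, compound 4, `COc1ccc(CN(C(=O)CBr)c2cc(OC)c(OC)c(OC)c2)cc1O`, is not yet measured. It differs from compound 2 in one place: bromo in place of methoxy on a saturated chain carbon bound to a carbonyl carbon. Everything else, the benzyl group with its methoxy and hydroxy, the trimethoxyphenyl ring, and the amide carbonyl, is kept.

Going by the values given here, no pair of compounds measured here differs by this same change, so there is no direct guide to its size or direction. With the methoxymethyl carbonyl of compound 2 exchanged for a bromomethyl carbonyl, the step from compound 2 to compound 4 is expected to be small, a 1.9-fold higher number from compound 2 to compound 4 (0.28 log units; within the scatter), possibly within the scatter. Compound 4 is expected to give about 150 nM, within a range from 30 nM to 800 nM.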

Compound 4, half-maximal inhibitory concentration: 140 nM
Estimate against measurement, compound 4: 1.1-fold (0.03 log units) above; the range from low to high includes it.
By their numbers in this assay, from the lowest: compounds 2 and 4 (each within the scatter of the next); then compound 3. At a limit, above all of these: compound 1.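

Going by these compounds alone, this is the first pair here that differs in one place only, so it gives the first direct reading of this position. In this assay bromo in place of methoxy on a saturated chain carbon bound to a carbonyl carbon gives a 1.8-fold higher number from compound 2 to compound 4 (0.25 log units; within the scatter) and so leaves the two compounds indistinguishable on this read-out, although the methoxy that leaves carries 1 hydrogen-bond acceptor and the bromo that enters carries none. At this one position, then, methoxymethyl and bromomethyl read alike on the core of compound 2, though nothing shown explains why.

One pair cannot show how much freedom this position allows, since both groups tested here are small and both sit on the same saturated chain carbon. From the compounds shown here alone, an amine, a carboxylic acid or a longer chain at this place could read the same or very differently, and it also remains open whether the same exchange would give a similar result on a compound with a different benzyl group.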